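The source may report more compounds than this note shows. Statements on the series, on what has been measured and on what is new or still open speak of the compounds shown alone.

Measured so far in a functional assay on UACC-62 cells (Homo sapiens); on this read-out lower numbers stand for stronger inhibition of growth and higher numbers for weaker inhibition of growth:
- Compound 1 `O=S(=O)(/C=C/c1ccc(Cl)cc1)Cc1ccc(Nc2ncnc3ccccc23)cc1`: 13000 nM
- Compound 2 `O=S(=O)(/C=C/c1ccc(F)cc1F)Cc1ccc(Nc2ncnc3ccccc23)cc1`: > 100000 nM, a limit of the assay and not a number

Compound 2 stands at the limit of > 100000 nM in this assay, at which 1 of the 2 values shown sits. Compound 3 `O=S(=O)(/C=C/c1ccc(C(F)(F)F)cc1F)Cc1ccc(Nc2ncnc3ccccc23)cc1` differs from it in one place: trifluoromethyl in place of fluoro on an aromatic carbon, with trifluoromethyl in place of fluoro on an aromatic carbon. Among the compounds with values here, the one measured step bearing on this is an at least 7.6-fold higher number from compound 1 to compound 2 (0.88 log units; beyond the scatter), which also changed the group on this aromatic ring. On that single step, a modest move towards stronger inhibition of growth is expected in this assay, though a further limit remains possible. The expected step is an at least 2.5-fold lower number from compound 2 to compound 3 (0.39 log units; beyond the scatter). For compound 3 the estimated value is 40000 nM, with an expected range from 10000 nM to 100000 nM.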

Compound 3, concentration for 50% growth inhibition: 100000 nM
The estimate for compound 3 lay 2.5-fold (0.40 log units) below the measured number; the range from low to high includes it.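

In this assay, the change of group gives a number no higher from compound 2 to compound 3 (the limit leaves the size open). The size of this step cannot be read because the value of compound 2 is a limit and not a number: the limit of > 100000 nM in this assay, at which 1 of the 3 values shown sits. The comparison with the 4-chlorophenyl group can be read, and it shows a 7.7-fold higher number from compound 1 to compound 3 (0.89 log units; beyond the scatter) as growth inhibition weakens. So 2-fluoro-4-(trifluoromethyl)phenyl, like 2,4-difluorophenyl, is a poorer group here than 4-chlorophenyl.

Still open, going by these compounds, is whether an amine or a carboxylic acid on this aromatic carbon would restore inhibition. The compounds shown also do not separate the effect of the fluoro group in compound 3 from that of its trifluoromethyl group.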